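Trimming One Methoxy Group: From Compound 2 to Compound 4

This account rests on a few compounds, and the source may have more. Where it says the series, first, only, none or still open, it means among the compounds named here.

Compound 1 `COc1ccc(-c2cc(/C=C/C(=O)c3ccc(N)cc3)[nH]n2)cc1`: -96%
Compound 2 `COc1cc(-c2cc(/C=C/C(=O)c3ccc(N)cc3)[nH]n2)cc(OC)c1OC`: -96%
Compound 3 `COc1cc(-c2cc(/C=C/C(=O)c3ccc(F)c(F)c3)[nH]n2)cc(OC)c1OC`: -40%

These three compounds were tested in a functional assay on A498 cells (Homo sapiens) for cytotoxicity, read by sulforhodamine B assay, with a stated time of 48 h, tested at 100 uM; on this read-out higher numbers stand for a weaker effect at the one concentration tested and lower numbers for a stronger effect. Compound 2 gives -96% there, level with compound 1 at the digits shown, and the two stand together at the low end of the three numbers, while compound 3 lies well above them. Compound 4 `COc1ccc(-c2cc(/C=C/C(=O)c3ccc(N)cc3)[nH]n2)cc1OC` differs from compound 2 by hydrogen in place of methoxy on an aromatic carbon. For the measured compounds named here, the only measured step, a number 56 percentage points higher from compound 2 to compound 3 (beyond the scatter), alters the group on the carbonyl carbon rather than a methoxy group, so it does not bear directly on this change. Compounds 1 and 2, which carry different numbers of methoxy groups on the shared core, show the same value, so little movement is expected. Compound 4 is therefore estimated at -96% (range -100% to -82%), a step of no change at the digits printed from compound 2 to compound 4 (within the scatter) expected to stay within the scatter.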

Compound 4, a percentage reported as activity, at one concentration (the size of the read-out at that concentration, not a potency): -98%
Compound 4: the middle estimate sits 2 percentage points above what was measured; the range from low to high includes it.
By their numbers in this assay, from the lowest: compounds 4, 1 and 2 (each within the scatter of the next); then compound 3.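

In this assay, replacing one methoxy group with hydrogen gives a number 2 percentage points lower from compound 2 to compound 4 (within the scatter), while the matching single addition of methoxy gives a number 2 percentage points lower from compound 1 to compound 4 (within the scatter). Compounds 1 and 2 differ in more than one place, so only these steps isolate a single methoxy group, and with the 4-aminophenyl group on the carbonyl carbon, hydrogen and methoxy cannot be told apart here. No available evidence explains this result. Still open, as far as these compounds go, is whether an amine or a longer chain such as ethoxy on this aromatic carbon would behave alike. From the compounds shown here alone, it is also open whether the same holds with the 3,4-difluorophenyl group of compound 3.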